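A few compounds are considered here, and "the series" means these few. Any claim that something is new, unique, unknown or untested is made for them only; others in the source may bear on it.

Compound 2, whose structure is `Cc1c(Nc2nc(N)c3c(C#N)c(N4CCC[C@H]4C)n(C)c3n2)cnn1[C@@H]1CCOC1`, is the strongest of three measured compounds in an assay on HEK293 cells for inhibition of Leucine-rich repeat serine/threonine-protein kinase 2 (Homo sapiens), with a stated time of 48 h (a higher number here means a weaker inhibitor, a lower number a stronger inhibitor), where compound 2 gives 180 nM. Compound 1, with structure `Cc1nn(CC2(O)COC2)cc1Nc1nc(N)c2c(C#N)c(N3CCC[C@H]3C)n(C)c2n1`, gives 410 nM in this assay, and compound 3, with structure `C[C@@H]1CCCN1c1c(C#N)c2c(N)nc(Nc3cn(C)nc3C(F)(F)F)nc2n1C`, gives 910 nM; both of these gaps to compound 2 lie beyond the usual scatter.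

Compound 4, with structure `Cc1c(Nc2nc(N)c3c(C#N)c(N4CCC[C@H]4C)n(C)c3n2)cnn1CC1(O)COC1`, has not yet been measured. It differs from compound 2 in one place: (3-hydroxyoxetan-3-yl)methyl in place of oxolan-3-yl on an aromatic nitrogen. Within the data shown here, no directly comparable pair among the measured compounds shows this exact change, so its effect here is not known. The same (3-hydroxyoxetan-3-yl)methyl group does appear in compound 1, where compound 1 gives 410 nM, a weaker result than compound 2, though compound 1 also differs from compound 4 elsewhere on its shared core.

Compound 4 is therefore expected to be somewhat weaker than compound 2, with an estimated step of a 1.9-fold higher number from compound 2 to compound 4 (0.29 log units; within the scatter) that may only just exceed the scatter. The estimate for compound 4 in this assay is 350 nM, with a likely range from 150 nM to 800 nM.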

Compound 4, half-maximal inhibitory concentration: 220 nM
The estimate for compound 4 lay 1.6-fold (0.20 log units) above the measured number; low and high end bracket the measured number.
By their numbers in this assay, from the lowest: compounds 2, 4 and 1 (each within the scatter of the next, the first and the last beyond it); then compound 3.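

In this assay, placing (3-hydroxyoxetan-3-yl)methyl in place of oxolan-3-yl on the aromatic nitrogen gives a 1.2-fold higher number from compound 2 to compound 4 (0.09 log units; within the scatter) and so the two compounds cannot be told apart. Among these compounds, this is the first direct reading at this position: on the shared core, a four-membered ring with a hydrogen-bond donor and a five-membered ring with a defined stereocentre give matching results in this pair. Nothing available accounts for this match. The compounds shown leave open whether an amine, a carboxylic acid or a longer carbon chain on this aromatic nitrogen would also stay within the scatter of compound 2. They also leave open whether the mirror-image form of the oxolan-3-yl group would give a matching result.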